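Butyl for Cyclopropyl: Expecting the Cytotoxicity of Compound 4

This account rests on a few compounds, and the source may have more. Where it says the series, first, only, none or still open, it means among the compounds named here.

Compound 3 `O=c1[nH]c(=O)n([C@@H]2O[C@H](CO)[C@@H](O)[C@H]2O)cc1C#CC1CC1` and compound 1 `CCCCC#Cc1cn([C@@H]2O[C@H](CO)[C@@H](O)[C@H]2O)c(=O)[nH]c1=O` share one core. In an ADME assay on Vero cells (Chlorocebus sabaeus) for cytotoxicity, read by MTT assay (a lower number here means that less compound is tolerated, a higher number that more compound is tolerated), compound 3 gives 133000 nM, and compound 1 gives 103000 nM. The step of a 1.3-fold lower number from compound 3 to compound 1 (0.11 log units; within the scatter) comes with butyl in place of cyclopropyl on a triple-bonded carbon. Compound 2 `O=c1[nH]cc(C#CC2CC2)c(=O)[nH]1` has a smaller core; how it differs from the core of compound 3 is not broken down here. In this assay compound 2 gives 252000 nM. Compound 4 `CCCCC#Cc1c[nH]c(=O)[nH]c1=O` is not yet measured; it differs from compound 2 by butyl in place of cyclopropyl on a triple-bonded carbon, the same change as before at the same place. Compound 4 is therefore expected to give about 190000 nM in this assay, between 100000 nM and 350000 nM. The expected step of a 1.3-fold lower number from compound 2 to compound 4 (0.12 log units; within the scatter) rests on the step of a 1.3-fold lower number from compound 3 to compound 1 (0.11 log units; within the scatter), which stayed within the scatter.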

Compound 4, half-maximal cytotoxic concentration: 253000 nM
Compound 4: middle estimate off by 1.3-fold (0.12 log units), on the low side; measured number inside the range.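

In this assay, butyl in place of cyclopropyl on a triple-bonded carbon came with a 1.0-fold higher number from compound 2 to compound 4 (0.00 log units; within the scatter). Set beside the earlier step, the change carried from one core to the other with no difference that can be told apart: the same change on two cores in this assay, a 1.3-fold lower number (0.11 log units; within the scatter) from compound 3 to compound 1 and a 1.0-fold higher number (0.00 log units; within the scatter) from compound 2 to compound 4, 1.3-fold (0.11 log units) apart, within the scatter of two such steps. Going by these compounds alone, this shows that on these two cores the swap leaves the number within the scatter, but it does not show that the step would stay this small on any other core, since each core offers only a single pair.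

The compounds shown leave open whether a longer chain or a chain ending in an amine, placed on the same triple-bonded carbon, would give steps that also agree across both cores in this assay.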